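Carbonyl substituent step in the shared core series

A few compounds are considered here, and "the series" means these few. Any claim that something is new, unique, unknown or untested is made for them only; others in the source may bear on it.

Measured so far in an assay on membranes from HeLa cells for displacement of a labelled ligand from adenosine receptor A3 (Homo sapiens), read by scintillation counting, with a stated time of 180 min, tested at 1 uM; on this read-out lower numbers stand for less inhibition and higher numbers for more inhibition at the one concentration tested (going by the name of the read-out):
compound 1 `CC1=C(C(=O)OCC(C)C)C(c2ccoc2)NC(=O)N1`: 16%
compound 2 `CC1=C(C(=O)OCC(C)C)C(c2cccs2)NC(=O)N1`: 11%
compound 3 `CC1=C(C(=O)OCC(C)C)C(c2ccoc2)NC(=O)N1C`: 16%

Compound 1 sits level with compound 3 in this assay, and compound 2 lies within the scatter of both. The two measured steps are small: a number 5 percentage points lower from compound 1 to compound 2 (within the scatter), and no change at the digits printed from compound 1 to compound 3 (within the scatter). Neither step touches the carbonyl carbon, so they say nothing direct about the change now at hand; they only show that two changes elsewhere on the core of compound 1 left the number where it was.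

Compound 4 `CC1=C(C(=O)CC(C)C)C(c2ccoc2)NC(=O)N1` differs from compound 1 by isobutyl in place of isobutoxy on a carbonyl carbon. Among the measured compounds shown here, no measured pair carries a change at this carbonyl carbon, so the expectation rests on the low level of compound 1, given by 16%, and on the absence of any step beyond the scatter so far. The expected step is therefore no change at the digits printed from compound 1 to compound 4 (within the scatter), with no direction claimed beyond the scatter.

Compound 4 is estimated at 16% in this assay, within a range from 2% to 32%.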

Compound 4, a percentage reported as inhibition, at one concentration (the size of the read-out at that concentration, not a potency): 18%
Beside the measured number, compound 4's estimate is 2 percentage points below it, and the stated range covers the measured number.
By their numbers in this assay, from the lowest: compounds 2, 1, 3 and 4 (each within the scatter of the next).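

In this assay, the carbonyl carbon now has a measured step of its own: isobutyl in place of isobutoxy gives a number 2 percentage points higher from compound 1 to compound 4 (within the scatter) and leaves the number where the other changes to the shared core left it. The earlier steps shown here touched only the ring substituent and the amide-type nitrogen, whereas this one shows that the oxygen of isobutoxy can be lost from this place without a step beyond the scatter, so at the one concentration tested the read-out does not separate the two groups. Nothing at hand explains why the number holds across this change.

Still open, from the compounds shown here alone, is whether any group on this carbonyl carbon can move the number beyond the scatter; an amide made from a simple amine, a carboxylic acid or a longer chain in this place would test that. Going by these compounds, all the values stay low at the one concentration tested, so whether isobutyl and isobutoxy would also stay together in a full potency measurement remains unknown.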